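Chloro to Cyano at a Different Ring Position

This account rests on a few compounds, and the source may have more. Where it says the series, first, only, none or still open, it means among the compounds named here.

Compound 1 `COc1ccc(C(N)=O)cc1/C=C/c1ccc(Cl)cc1` and compound 2 `COc1ccc(C(N)=O)cc1/C=C/c1ccc(C#N)cc1` share one core and differ in a single group. In an ADME assay on HCT-116 cells (Homo sapiens) for antiproliferative activity (a higher number here means a weaker inhibitor, a lower number a stronger inhibitor), compound 1 gives 7100 nM, and compound 2 gives 16000 nM. The change between them is cyano in place of chloro on an aromatic carbon and it produced a 2.3-fold higher number from compound 1 to compound 2 (0.35 log units; beyond the scatter).

Compound 3 `COc1ccc(C(N)=O)cc1/C=C/c1cccc(Cl)c1` has the same atoms as compound 1, joined differently; the difference between the two cores is not broken down here. In this assay compound 3 gives 15000 nM.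

Compound 4 `COc1ccc(C(N)=O)cc1/C=C/c1cccc(C#N)c1` has not yet been measured. It arises from compound 3 by cyano in place of chloro on an aromatic carbon. This is the same kind of change as that from compound 1 to compound 2, but the surroundings differ: in the earlier pair the group sits para to a large group, whereas here it sits meta to a large group. For the measured compounds named here, only that one earlier step is available, so the expectation rests on it alone. Compound 4 is expected to show a 2.2-fold higher number from compound 3 to compound 4 (0.34 log units; beyond the scatter) in this assay, a step similar in size to a 2.3-fold higher number from compound 1 to compound 2 (0.35 log units; beyond the scatter). For compound 4 the estimate is 33000 nM, with a likely range from 15000 nM to 75000 nM.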

Compound 4, half-maximal inhibitory concentration: 19000 nM
The estimate for compound 4 lay 1.7-fold (0.24 log units) above the measured number, within the range that was stated.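

In this assay, placing cyano where chloro stood on the second core gives a 1.3-fold higher number from compound 3 to compound 4 (0.10 log units; within the scatter), so on this core the change cannot be told apart from the ordinary spread of repeated measurements. Set beside the step on the first core, the new step does not differ from it by more than two such steps can differ by chance: the same change on two cores in this assay, a 2.3-fold higher number (0.35 log units; beyond the scatter) from compound 1 to compound 2 and a 1.3-fold higher number (0.10 log units; within the scatter) from compound 3 to compound 4, 1.8-fold (0.25 log units) apart, within the scatter of two such steps. For the compounds shown here, the change can therefore be carried from one core to the other without any sign of a different outcome, but this is only a single pair of steps, and it does not prove that the change acts the same way on both cores, nor that it has a real effect on the second.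

The compounds shown leave open how other groups would behave at these places on the ring, such as an amine or a carboxylic acid in place of chloro. They also leave open whether the same comparison would hold on any further core.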